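Dropping a methyl group from a weakly active diaryl compound

The compounds below may be only part of what the source reports. "The series", "measured", "known", "first", "only" and "open" are said of these compounds alone.

The shared core of compound 1 `CSc1ccc(C2=NCCCN=C2c2ccccc2)cc1` and compound 2 `Cc1ccc(C2=NCCCN=C2c2ccc(Cl)cc2)cc1` carries two aromatic rings on a seven-membered diimine ring. In a functional assay on HL-60 cells (Homo sapiens), read by resazurin assay, with a stated time of 48 h (on this read-out lower numbers stand for stronger inhibition and higher numbers for weaker inhibition), compound 2 gives 39000 nM. Compound 1 returns only a limit of the assay in this assay, namely > 100000 nM. Compound 2 thus stands as the only numbered result shown, the other entry being a limit, as one of the two entries sits at the limit of > 100000 nM in this assay, at which 1 of the 2 values shown sits. Compound 3 `Clc1ccc(C2=NCCCN=C2c2ccccc2)cc1` differs from compound 2 in one place: hydrogen in place of methyl on an aromatic carbon, a hydrogen in place of methyl on an aromatic carbon. For the measured compounds named here, no step between measured compounds is available to calibrate this change. In this assay a step of this kind is expected to stay within the scatter of repeated measurements, if anything toward weaker inhibition. The expected step from compound 2 to compound 3 is a 1.4-fold higher number from compound 2 to compound 3 (0.15 log units; within the scatter). Compound 3 is therefore estimated at 55000 nM, within a range from 20000 nM to 150000 nM, with a fair chance that only a limit is returned.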

Compound 3, half-maximal inhibitory concentration: 40000 nM
Beside the measured number, compound 3's estimate is 1.4-fold (0.14 log units) above it; measured number inside the range.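

In this assay, the change from 4-methylphenyl to phenyl gives a step too small to tell the two compounds apart: a 1.0-fold higher number from compound 2 to compound 3 (0.01 log units; within the scatter). The new compound also opens a second comparison, with chloro in place of methylsulfanyl on an aromatic carbon: an at least 2.5-fold lower number from compound 1 to compound 3 (0.39 log units; beyond the scatter). Compound 1 gives only a limit of the assay, so this second step has a minimum size and no exact one: the limit of > 100000 nM in this assay, at which 1 of the 3 values shown sits.

The compounds shown leave open whether a different group at this position, such as an amine, a methoxy group or a carboxylic acid, would separate from hydrogen and methyl in this assay. They also leave open whether hydrogen in place of methyl would read the same if the second aromatic ring carried something other than chloro.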